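Aromatase series: bis(cyanophenyl)methyl triazoles, pendant group variation

This account rests on a few compounds, and the source may have more. Where it says the series, first, only, none or still open, it means among the compounds named here.

Measured so far in an assay on isolated protein for inhibition of Aromatase (Homo sapiens), read by fluorescence and colorimetric assay, with a stated time of 30 min; a higher number here means a weaker inhibitor, a lower number a stronger inhibitor:
compound 1, `CCCCCCCCCCc1cn(C(c2ccc(C#N)cc2)c2ccc(C#N)cc2)nn1`, 16000 nM
compound 2, `N#Cc1ccc(C(c2ccc(C#N)cc2)n2cc(C3CCCCC3)nn2)cc1`, 19300 nM
compound 3, `N#Cc1ccc(OCc2cn(C(c3ccc(C#N)cc3)c3ccc(C#N)cc3)nn2)cc1`, 4640 nM

Compound 3 gives the lowest number of the three in this assay. The step of a 3.4-fold lower number from compound 1 to compound 3 (0.54 log units; beyond the scatter) and the step of a 4.2-fold lower number from compound 2 to compound 3 (0.62 log units; beyond the scatter) both lie beyond the scatter, while the step of a 1.2-fold higher number from compound 1 to compound 2 (0.08 log units; within the scatter) does not. Compound 4, `N#Cc1ccc(C(c2ccc(C#N)cc2)n2cc(COc3ccc(-c4ccccc4)cc3)nn2)cc1`, is not yet measured. It differs from compound 3 by phenyl in place of cyano on an aromatic carbon. Among the compounds with values here, no measured pair changes the outer substituent of that pendant ring; the two steps into compound 3 only show that the (4-cyanophenoxy)methyl arm beats the decyl and cyclohexyl arms by a modest margin. Nothing in the set says whether the cyano on that arm matters. The expectation for compound 4 is therefore a step of about a 1.1-fold higher number from compound 3 to compound 4 (0.03 log units; within the scatter), which is within the scatter. Compound 4 is estimated at 5000 nM in this assay, with a range of 1500 nM to 16000 nM.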

Compound 4, half-maximal inhibitory concentration: 13400 nM
For compound 4 the middle estimate is 2.7-fold (0.43 log units) below the measured one, and the stated range covers the measured number.
By their numbers in this assay, from the lowest: compound 3; then compounds 4, 1 and 2 (each within the scatter of the next).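

In this assay, the outer substituent of the pendant ring now has a first reading: on an aromatic carbon para to a large group, phenyl in place of cyano gives a 2.9-fold higher number from compound 3 to compound 4 (0.46 log units; beyond the scatter) and is a change beyond the scatter. The (4-cyanophenoxy)methyl arm of compound 3 therefore keeps its lowest number only as a whole, since keeping the phenoxymethyl part while exchanging the cyano does not preserve that number. Nothing available explains the shift.

Still open, on these data alone, is whether the loss follows from removing cyano or from adding phenyl, so a plain hydrogen, a fluorine, a methoxy or an amine on the same carbon would help separate the two. Also open, as far as these compounds go, is whether a longer chain in place of the methylene link would move the number in either direction.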